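Sulfonamide series: 3-fluorophenyl versus 3-chloro-2-fluorophenyl

The compounds below may be only part of what the source reports. "The series", "measured", "known", "first", "only" and "open" are said of these compounds alone.

Three compounds of the series carry a number in a functional assay on A-431 cells (Homo sapiens) for antiproliferative activity, read by MTT assay, with a stated time of 72 h; on this read-out higher numbers stand for weaker inhibition and lower numbers for stronger inhibition. Compound 1 `COc1cc2ncnc(Nc3cccc(F)c3)c2cc1OCCCCC(=O)Nc1ccc(S(N)(=O)=O)cc1` gives 29900 nM. Compound 2 `COc1cc2ncnc(Nc3cccc(Cl)c3F)c2cc1OCCCCC(=O)Nc1ccc(S(N)(=O)=O)cc1` gives 5560 nM, and compound 3 `NS(=O)(=O)c1ccc(NC(=S)Nc2ccc3ncnc(Nc4cccc(Cl)c4F)c3c2)cc1` gives 13100 nM. Compound 2 and compound 1 share a core and differ in one place, (3-fluorophenyl in place of 3-chloro-2-fluorophenyl on a nitrogen on an aromatic ring); that change gave a 5.4-fold higher number from compound 2 to compound 1 (0.73 log units; beyond the scatter). Compound 3 carries the same 3-chloro-2-fluorophenyl group as compound 2 on a different core; the difference between the two cores is not broken down here. Compound 3 stands between the other two, with compound 2 giving the lower number and compound 1 the higher.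

Compound 4 `NS(=O)(=O)c1ccc(NC(=S)Nc2ccc3ncnc(Nc4cccc(F)c4)c3c2)cc1` is not yet measured. It differs from compound 3 in one place, (3-fluorophenyl in place of 3-chloro-2-fluorophenyl on a nitrogen on an aromatic ring), the same change as between compound 2 and compound 1, at a place described in the same words. In this assay a step in the same direction is expected, a 3.8-fold higher number from compound 3 to compound 4 (0.58 log units; beyond the scatter), resting only on a 5.4-fold higher number from compound 2 to compound 1 (0.73 log units; beyond the scatter) seen on the other core; a single pair supports it, so a somewhat smaller step is assumed. Compound 4 is estimated at 50000 nM, with a range from 18000 nM to 150000 nM.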

Compound 4, half-maximal inhibitory concentration: 30100 nM
The estimate for compound 4 lay 1.7-fold (0.22 log units) above the measured number, and the stated range covers the measured number.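

In this assay the swap of 3-chloro-2-fluorophenyl for 3-fluorophenyl gives a 2.3-fold higher number from compound 3 to compound 4 (0.36 log units; beyond the scatter) on the second core, so the direction of the change carries over from one core to the other. The two steps do not differ in size beyond what repeated measurements allow: the same change on two cores in this assay, a 5.4-fold higher number (0.73 log units; beyond the scatter) from compound 2 to compound 1 and a 2.3-fold higher number (0.36 log units; beyond the scatter) from compound 3 to compound 4, 2.3-fold (0.37 log units) apart, within the scatter of two such steps. This rests on two pairs and two cores, so it gives no rule for other cores in the series, does not explain why the number moves, and does not show how much of the step belongs to the loss of the chlorine alone.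

Still open, as far as these compounds go, is whether the same direction holds for other groups on that nitrogen, such as 3-chlorophenyl or 3-ethynylphenyl, on either core. Also open, from the compounds shown here alone, is how either core would read with a carboxylic acid in place of the sulfonamide, or with a shorter or longer chain in compound 2.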